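This account rests on a few compounds, and the source may have more. Where it says the series, first, only, none or still open, it means among the compounds named here.

Measured so far:
compound 1 `CC(NC(=O)/C=C/c1ccc(NC(=O)Nc2ccc(Cl)c(C(F)(F)F)c2)cc1)c1ccccc1`, 20800 nM
compound 2 `CC(NC(=O)/C=C/Oc1ccc(NC(=O)Nc2cc(C(F)(F)F)ccc2Cl)cc1)c1ccccc1`, 16000 nM
compound 3 `CC(NC(=O)/C=C/Oc1ccc(NC(=O)Nc2ccc(Cl)c(C(F)(F)F)c2)cc1)c1ccccc1`, 20700 nM

The three compounds were tested in a functional assay on A-375 cells (Homo sapiens) for inhibition, read by MTT assay, with a stated time of 120 h; on this read-out higher numbers stand for weaker inhibition and lower numbers for stronger inhibition. Compound 1 gives 20800 nM, compound 3 gives 20700 nM and compound 2 gives 16000 nM; all three numbers sit within the scatter of one another, so no order among them can be stated.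

Compounds 2 and 3 share a core and differ at one spot: 2-chloro-5-(trifluoromethyl)phenyl in place of 4-chloro-3-(trifluoromethyl)phenyl on an amide-type nitrogen. This change gave a 1.3-fold lower number from compound 3 to compound 2 (0.11 log units; within the scatter). The same change separates compound 1 from compound 4 `CC(NC(=O)/C=C/c1ccc(NC(=O)Nc2cc(C(F)(F)F)ccc2Cl)cc1)c1ccccc1`: 2-chloro-5-(trifluoromethyl)phenyl in place of 4-chloro-3-(trifluoromethyl)phenyl on an amide-type nitrogen. The place of the change is described the same way in both pairs, so it is the same change on two cores. How the core of compound 1 differs from that of compound 3 is not broken down here.

For compound 4 in this assay the step from compound 1 is expected to be a 1.2-fold lower number from compound 1 to compound 4 (0.09 log units; within the scatter), because the matched pair gave a 1.3-fold lower number from compound 3 to compound 2 (0.11 log units; within the scatter) and compound 1 starts from 20800 nM. Compound 4 is therefore estimated at 17000 nM, with a likely range from 8000 nM to 40000 nM.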

Compound 4, half-maximal inhibitory concentration: 40900 nM
Compound 4: the middle estimate sits 2.4-fold (0.38 log units) below what was measured; measured number outside the range, above it.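

In this assay, placing 2-chloro-5-(trifluoromethyl)phenyl where 4-chloro-3-(trifluoromethyl)phenyl stood on an amide-type nitrogen gave a 2.0-fold higher number from compound 1 to compound 4 (0.29 log units; within the scatter) on the core of compound 1. Set beside the earlier step on the other core, this result gives no sign that the core alters what the change does: the same change on two cores in this assay, a 1.3-fold lower number (0.11 log units; within the scatter) from compound 3 to compound 2 and a 2.0-fold higher number (0.29 log units; within the scatter) from compound 1 to compound 4, 2.5-fold (0.41 log units) apart, within the scatter of two such steps. Among these compounds, this shows only that neither core gave a step beyond the scatter for this change; it does not show that the change has any real effect on either core, nor that the two steps are truly alike, and a direction cannot be read from either of them.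

The compounds shown leave open whether a carboxylic acid or an amine in place of the trifluoromethyl group on this phenyl ring would give a step beyond the scatter. They also leave open how the same change would behave on a third core.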